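Pyridinylethyl in place of a halogenated benzyl on the triazole

This account rests on a few compounds, and the source may have more. Where it says the series, first, only, none or still open, it means among the compounds named here.

Measured compounds: compound 1 `Ic1ccc(Cn2cc(CCCOc3cccc4cccnc34)nn2)cc1`; compound 2 `Clc1ccc(Br)cc1Cn1cc(CCCOc2cccc3cccnc23)nn1`.

Among the compounds with values here, in an ADME assay on HaCaT cells (Homo sapiens) for inhibition, read by sulforhodamine B assay, with a stated time of 48 h (on this read-out higher numbers stand for weaker inhibition of growth and lower numbers for stronger inhibition of growth), compound 2 gives 4.9 ug/mL, the only plain number among the two results. For compound 1 this assay reports only a limit, > 250 ug/mL. Within the data shown here, the one measured step, an at least 51-fold lower number from compound 1 to compound 2 (1.70 log units; beyond the scatter), is large, with one end sitting at the limit of > 250 ug/mL in this assay, at which 1 of the 2 values shown sits. Compound 3 `c1cncc(CCCn2cc(CCCOc3cccc4cccnc34)nn2)c1` differs from compound 2 by 2-(pyridin-3-yl)ethyl in place of 5-bromo-2-chlorophenyl on a saturated chain carbon bound to an aromatic nitrogen. That step leads away from compound 2 rather than repeating the measured one, so the number is expected to rise, perhaps toward the limit. Compound 3 is estimated at 60 ug/mL, between 10 ug/mL and 250 ug/mL. The expected step is a 12-fold higher number from compound 2 to compound 3 (1.09 log units; beyond the scatter).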

Compound 3, concentration for 50% growth inhibition: 25 ug/mL
Compound 3: the middle estimate sits 2.4-fold (0.38 log units) above what was measured, within the range that was stated.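

At this place, on a saturated chain carbon bound to an aromatic nitrogen, a halogen-free 2-(pyridin-3-yl)ethyl still gives a plain number in this assay, with a 5.1-fold higher number from compound 2 to compound 3 (0.71 log units; beyond the scatter). Against the 4-iodophenyl the same group gives an at least 10-fold lower number from compound 1 to compound 3 (1.00 log units; beyond the scatter), so the halogenated groups span both sides of it. That second step is only a bound: the limit of > 250 ug/mL in this assay, at which 1 of the 3 values shown sits.

The compounds shown leave open whether the ring nitrogen or the ethyl link accounts for the change. A 2-phenylethyl group, or an amine in place of the pyridine ring, would separate the two.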